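Fluorine in Place of Hydrogen, Tried on a Second Core

The compounds below may be only part of what the source reports. "The series", "measured", "known", "first", "only" and "open" are said of these compounds alone.

Measured so far:
compound 1, `COc1ccc(Br)c(-c2nc3ccccc3[nH]2)c1O`: 2480 nM
compound 2, `COc1cc(Br)c(-c2nc3ccccc3[nH]2)cc1OC`: 1510 nM
compound 3, `COc1ccc(Br)c(-c2nc3cc(F)ccc3[nH]2)c1O`: 2170 nM

Of the compounds shown here, three have been measured in an assay for inhibition of Alpha amylase (Homo sapiens), with a stated time of 10 min; a higher number here means a weaker inhibitor, a lower number a stronger inhibitor. Compound 1 `COc1ccc(Br)c(-c2nc3ccccc3[nH]2)c1O` gives 2480 nM. Compound 2 `COc1cc(Br)c(-c2nc3ccccc3[nH]2)cc1OC` gives 1510 nM; its core is not the core of compound 1, and the difference between the two cores is not broken down here. Compound 3 `COc1ccc(Br)c(-c2nc3cc(F)ccc3[nH]2)c1O` gives 2170 nM. Compound 3 differs from compound 1 by a single change, (fluoro in place of hydrogen on an aromatic carbon), and that change produced a 1.1-fold lower number from compound 1 to compound 3 (0.06 log units; within the scatter). The three values all lie within the scatter of one another, so none of the three can be set apart from the others on the numbers alone.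

Compound 4 `COc1cc(Br)c(-c2nc3cc(F)ccc3[nH]2)cc1OC` has not yet been measured in this assay. It differs from compound 2 by fluoro in place of hydrogen on an aromatic carbon. The place of the entering fluoro is described in the same words for both pairs, so this is the same change, now made on the core of compound 2 instead of the core of compound 1. The change has been seen only once among the measured compounds. Because its one earlier outcome was a 1.1-fold lower number from compound 1 to compound 3 (0.06 log units; within the scatter), the step to compound 4 is expected to be small, on the order of a 1.1-fold lower number from compound 2 to compound 4 (0.03 log units; within the scatter). Compound 4 is therefore estimated at 1400 nM in this assay. The range around that estimate for compound 4 runs from 700 nM to 2800 nM. The measurement will show whether the second core behaves like the first.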

Compound 4, half-maximal inhibitory concentration: 1570 nM
The estimate for compound 4 lay 1.1-fold (0.05 log units) below the measured number, and the stated range covers the measured number.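

In this assay, within the data shown here, fluoro in place of hydrogen on an aromatic carbon of the core of compound 2 gave a 1.0-fold higher number from compound 2 to compound 4 (0.02 log units; within the scatter), so the step cannot be told from no step at all. Set beside the earlier case, the two outcomes do not differ: the same change on two cores in this assay, a 1.1-fold lower number (0.06 log units; within the scatter) from compound 1 to compound 3 and a 1.0-fold higher number (0.02 log units; within the scatter) from compound 2 to compound 4, 1.2-fold (0.07 log units) apart, within the scatter of two such steps. Among these compounds, this shows that, on these two cores and at this one place, the change behaved alike and left the number within the scatter each time, but it rests on only two pairs and does not show that the same would hold on any further core or at any other place on the ring.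

The compounds shown leave open whether a different group on that aromatic carbon, such as an amine or a carboxylic acid, would give a step that stands clear of the scatter. They also leave open how the two cores compare part by part, since the difference between them is not broken down into single changes.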